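A Carbamoyl Group Replaces a Sulfonyl Group

This account rests on a few compounds, and the source may have more. Where it says the series, first, only, none or still open, it means among the compounds named here.

In a functional assay on MDA-MB-436 cells (Homo sapiens) for antiproliferative activity, read by MTT assay, with a stated time of 48 h (a lower number here means a stronger inhibitor, a higher number a weaker inhibitor), compound 1 (`C=CS(=O)(=O)N1CCN(c2ncnc3sc(-c4ccc(N5CCN(C)CC5)cc4)cc23)[C@@H](C)C1`) gives 6920 nM and compound 2 (`CN1CCN(c2ccc(-c3cc4c(N5CCN(S(=O)(=O)/C=C/c6ccccc6)CC5)ncnc4s3)cc2)CC1`) gives 8670 nM in the same test. These two numbers lie within the scatter of each other, so compound 2 stands level with compound 1. Compound 3 (`COc1ccc(NC(=O)N2CCN(c3ncnc4sc(-c5ccc(N6CCN(C)CC6)cc5)cc34)CC2)cc1`) carries (4-methoxyphenyl)carbamoyl in place of (2-phenylethenyl)sulfonyl on an amine nitrogen in a ring. Going by the values given here, no measured pair shows such a change, so the estimate is cautious. A modest step toward a lower number is expected in this assay (a 1.7-fold lower number from compound 2 to compound 3 (0.24 log units; within the scatter)). Compound 3 is estimated at 5000 nM with an expected range of 1500 nM to 15000 nM in this test.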

Compound 3, half-maximal inhibitory concentration: 30100 nM
For compound 3 the middle estimate is 6.0-fold (0.78 log units) below the measured one; the whole stated range lies below it.
By their numbers in this assay, from the lowest: compounds 1 and 2 (each within the scatter of the next); then compound 3.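

At this amine nitrogen in a ring, the attached group matters: in this assay, (4-methoxyphenyl)carbamoyl in place of (2-phenylethenyl)sulfonyl gives a 3.5-fold higher number from compound 2 to compound 3 (0.54 log units; beyond the scatter). The two groups have the same heavy-atom count, yet the entering group brings a hydrogen-bond donor and a nitrogen where the leaving group has sulfur. No available evidence explains this step. The compounds shown leave open whether the carbamoyl link or the 4-methoxyphenyl part goes with the higher number. Going by these compounds, how a plain phenylcarbamoyl or an acetyl group would stand on this nitrogen also remains open.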